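Nucleoside series: dimethylamino in place of benzylamino

The compounds below may be only part of what the source reports. "The series", "measured", "known", "first", "only" and "open" are said of these compounds alone.

Measured so far:
Compound 1 `OC[C@H]1O[C@@H](n2cnc3c(NCc4ccccc4)nccc32)C[C@@H]1O` — in a functional assay on the whole organism (Pleural cavity) with Rattus norvegicus as the target (on this read-out lower numbers stand for an effect already at smaller amounts and higher numbers for an effect only at larger amounts of compound), compound 1 gives only a limit, > 9 mg/kg.
Compound 2 `Nc1nccc2c1ncn2[C@H]1C[C@H](O)[C@@H](CO)O1` — compound 2 gives 10 mg/kg.
Compound 3 `OC[C@H]1OC(n2cnc3c(NCc4ccccc4)nccc32)[C@H](O)[C@@H]1O` — compound 3 gives only a limit, > 9 mg/kg.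

Compound 3 thus stands at the limit of the assay, the position also held by compound 1 (the limit of > 9 mg/kg in this assay, at which 2 of the 3 values shown sit). Going by the values given here, the one step between measured compounds that differ in one place, a step that the limit leaves unreadable from compound 1 to compound 2, is left unreadable by that limit, so its size is unknown.

Compound 4 `CN(C)c1nccc2c1ncn2C1O[C@H](CO)[C@@H](O)[C@H]1O` differs from compound 3 as follows: dimethylamino in place of benzylamino on an aromatic carbon. Among the compounds with values here, no measured step covers this change, and the starting point is itself only a limit. Compound 4 is therefore estimated at 12 mg/kg, with a range from 5 mg/kg to 30 mg/kg. The step that the limit leaves unreadable from compound 3 to compound 4 is expected to fall within the scatter.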

Compound 4, dose for half-maximal effect: > 9 mg/kg
Compound 4 gave a limit, no number; the forecaster's own chance of this, stated with the estimate: 50%; the middle value lies beyond the limit too.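

Compound 3 and compound 4 both give only a limit in this assay, and no step between them can be read: the limit of > 9 mg/kg in this assay, at which 3 of the 4 values shown sit.

The compounds shown leave open how dimethylamino and benzylamino compare on the shared core.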